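Urea aryl swap on a cytotoxicity read-out

A few compounds are considered here, and "the series" means these few. Any claim that something is new, unique, unknown or untested is made for them only; others in the source may bear on it.

Measured so far:
- compound 1 `CCNc1cc(-c2ccc(NC(=O)Nc3ccc(C)cc3)cc2C)ccn1`: 22000 nM
- compound 2 `CCNc1cc(-c2ccc(NC(=O)Nc3cccc(Cl)c3)cc2C)ccn1`: 16600 nM

Both compounds were tested in a functional assay on BT-483 cells (Homo sapiens) for cytotoxicity, read by MTT assay, with a stated time of 24 h (on this read-out higher numbers stand for weaker inhibition and lower numbers for stronger inhibition), where compound 1 gives 22000 nM and compound 2 gives 16600 nM. Compound 2 has the lowest of the two numbers, but its step to compound 1 is small: a 1.3-fold lower number from compound 1 to compound 2 (0.12 log units; within the scatter). The two compounds therefore cannot be told apart on this read-out.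

The next compound, compound 3 `CCNc1cc(-c2ccc(NC(=O)Nc3ccc(OC)cc3)cc2C)ccn1`, is not yet measured. It differs from compound 2 in one place: 4-methoxyphenyl in place of 3-chlorophenyl on an amide-type nitrogen. Among the compounds with values here, the only step that bears on it is the exchange of one aryl group for another on the same nitrogen, which moved the number by a 1.3-fold lower number from compound 1 to compound 2 (0.12 log units; within the scatter). A change of similar kind is expected to stay within the scatter, so the step of a 1.2-fold higher number from compound 2 to compound 3 (0.08 log units; within the scatter) is estimated as essentially flat. For compound 3 the expected value is 20000 nM, with a range from 9000 nM to 45000 nM.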

Compound 3, half-maximal inhibitory concentration: 25800 nM
Compound 3: middle estimate off by 1.3-fold (0.11 log units), on the low side; the range from low to high includes it.
By their numbers in this assay, from the lowest: compounds 2, 1 and 3 (each within the scatter of the next).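

Placing 4-methoxyphenyl instead of 3-chlorophenyl on the amide-type nitrogen gives a 1.6-fold higher number from compound 2 to compound 3 (0.19 log units; within the scatter) in this assay, while methoxy in place of methyl on an aromatic carbon gives a 1.2-fold higher number from compound 1 to compound 3 (0.07 log units; within the scatter). The entering 4-methoxyphenyl counts one hydrogen-bond acceptor where 3-chlorophenyl counts none, yet compound 3 cannot be told apart from compound 1 or compound 2, so this position has so far shown no readable response to any of the three aryl groups. No outside measurement is available to interpret this result.

From the compounds shown here alone, all three compounds carry a substituted phenyl group here, so it remains open whether an aryl ring bearing an amine or a carboxylic acid, or a simple alkyl chain in place of the ring, would move the number beyond the scatter.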